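Methoxy addition on two aromatic arms of the shared core

The compounds below may be only part of what the source reports. "The series", "measured", "known", "first", "only" and "open" are said of these compounds alone.

Of the compounds shown here, three on a shared core have been measured in a functional assay on NCI-H460 cells (Homo sapiens) for antiproliferative activity, with a stated time of 72 h; a lower number here means a stronger inhibitor, a higher number a weaker inhibitor. Compound 2 `C=CC[C@H]1C[C@]2([C@H](C)Cc3ccc(OC)cc3)OCOC2=CC1=O` gives 120 nM. Compound 1 `C=CC[C@H]1C[C@]2([C@H](C)Cc3ccc(OC)c(OC)c3)OCOC2=CC1=O` carries methoxy in place of hydrogen on an aromatic carbon and gives 320 nM; the step is a 2.7-fold higher number from compound 2 to compound 1 (0.43 log units; beyond the scatter). Compound 3 `C=CC[C@H]1C[C@]2([C@@H](C)Cc3ccc(OC)nc3)OCOC2=CC1=O` has a core that differs from that of compound 2 in a way that is not broken down here. In this assay compound 3 gives 330 nM. The values of compound 3 and compound 1 lie within the scatter of each other, while compound 3 sits further from compound 2.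

Compound 4 `C=CC[C@H]1C[C@]2([C@@H](C)Cc3cnc(OC)c(OC)c3)OCOC2=CC1=O` is not yet measured. It differs from compound 3 by methoxy in place of hydrogen on an aromatic carbon. This is the same kind of change as that from compound 2 to compound 1, but not the same: in compound 1 the methoxy enters on a six-membered aromatic ring of carbon only, whereas in compound 4 it enters on a six-membered aromatic ring with 1 nitrogen, two atoms from the ring nitrogen. Among the compounds with values here, only one measured instance of this kind of change is available, so the expectation rests on it alone.

The step of a 2.6-fold higher number from compound 3 to compound 4 (0.41 log units; beyond the scatter) is expected to be roughly as large as the earlier one because that earlier step gave a 2.7-fold higher number from compound 2 to compound 1 (0.43 log units; beyond the scatter). Compound 4 is therefore estimated at about 850 nM, with a range from 350 nM to 2200 nM. A number, not a limit, is expected from this assay.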

Compound 4, half-maximal inhibitory concentration: > 20000 nM
Compound 4 was reported as a limit; the forecaster's own chance of this, stated with the estimate: 5%; middle value at least 23-fold (1.37 log units) away from the limit.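

The replacement of hydrogen by methoxy on an aromatic carbon raises the number on both cores, but on the core of compound 3 it gives an at least 60-fold higher number from compound 3 to compound 4 (1.78 log units; beyond the scatter), and the size of the step does not carry over from one core to the other: the same change on two cores in this assay, a 2.7-fold higher number (0.43 log units; beyond the scatter) from compound 2 to compound 1 and an at least 60-fold higher number (1.78 log units; beyond the scatter) from compound 3 to compound 4, at least 22-fold (1.35 log units) apart, beyond the scatter of two such steps Compound 4 gives > 20000 nM in this assay, which is a limit of the assay and not a number, so the step on this core has a lower bound but no known size. With only two instances, the result does not show which feature of the cores accounts for the gap, whether the ring nitrogen or another part of the difference between them, and it gives no rule for any further core.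

The compounds shown leave open whether the loss on the nitrogen-containing ring belongs to methoxy itself or would also appear with another group in the same place, such as a hydroxyl, an amine, a fluorine or an ethoxy. Within the data shown here, they also leave open whether compound 3 can be improved by a group placed elsewhere on that ring, since this series so far offers a single change on it.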